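Pyrazolopyridine and pyrimidinone analogues: methyl for phenyl

The compounds below may be only part of what the source reports. "The series", "measured", "known", "first", "only" and "open" are said of these compounds alone.

Measured so far:
compound 1 `COCCNc1nc(C)cc2c1c(N)nn2C`, 4%
compound 2 `COCCNc1nc(-c2ccccc2)cc2c1c(N)nn2C`, 1%
compound 3 `Cc1cc2nc(-c3ccccc3)nc(N)c2c(=O)[nH]1`, 5%

Three compounds have been run in an assay on isolated protein for inhibition of serine/threonine-protein kinase D2 (Homo sapiens), read by mobility shift assay, tested at 30 uM (on this read-out higher numbers stand for more inhibition at the one concentration tested (going by the name of the read-out) and lower numbers for less inhibition), and all three sit at the low end of that read-out. Compound 2 gives 1%, compound 1 gives 4%, and compound 3 gives 5%. Going by the values given here, the step of a number 3 percentage points higher from compound 2 to compound 1 (within the scatter) is the one measured pair that differs in a single place: methyl in place of phenyl on an aromatic carbon. Compound 3 has a different core from compound 2; the difference between the two cores is not broken down here.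

Compound 4 `Cc1nc(N)c2c(=O)[nH]c(C)cc2n1` has not yet been run. It relates to compound 3 by the same kind of change: methyl in place of phenyl on an aromatic carbon. The surroundings differ from the earlier pair, where the carbon carrying the group is next to the ring nitrogen and meta to a (2-methoxyethyl)amino group; in compound 4 it is between two ring nitrogen atoms and meta to an amino group.

For compound 4 in this assay the step is expected to be a number 2 percentage points higher from compound 3 to compound 4 (within the scatter), resting on the earlier step of a number 3 percentage points higher from compound 2 to compound 1 (within the scatter), which stayed within the scatter. Compound 4 is therefore estimated at 7%, with a range from -5% to 18%.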

Compound 4, a percentage reported as inhibition, at one concentration (the size of the read-out at that concentration, not a potency): 6%
For compound 4 the middle estimate is 1 percentage points above the measured one; the measured number falls inside the stated range.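

Read in this assay the change of methyl in place of phenyl on an aromatic carbon gives a number 1 percentage points higher from compound 3 to compound 4 (within the scatter) and so again leaves no step beyond the scatter. Set beside the earlier pair, the two steps do not differ: the same change on two cores in this assay, a number 3 percentage points higher (within the scatter) from compound 2 to compound 1 and a number 1 percentage points higher (within the scatter) from compound 3 to compound 4, 2 percentage points apart, within the scatter of two such steps. This shows that the change carries from one core to the other with no difference that can be separated from the scatter, but all four numbers sit at the low end of the read-out, so it does not show that a step of this size would hold on a compound with clear inhibition.

Left open is whether any other group on this aromatic carbon, such as an amine, a carboxylic acid or a longer chain, moves the number beyond the scatter. Also open, as far as these compounds go, is whether replacing the (2-methoxyethyl)amino group on the core of compound 1 does so.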